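A few compounds are considered here, and "the series" means these few. Any claim that something is new, unique, unknown or untested is made for them only; others in the source may bear on it.

Compound 1, `COc1cc(OC)c(OC)cc1/C=C/COC(=O)/C=C/c1ccc(F)cc1`: 0%
Compound 2, `COc1cc(OC)c(OC)cc1/C=C/COC(=O)/C=C/c1ccc(Cl)cc1`: 25%
Compound 3, `COc1cc(OC)c(OC)cc1/C=C/COC(=O)/C=C/c1cc(OC)c(OC)c(OC)c1OC`: 0%

Of the compounds shown here, three that share a common core have been tested in a functional assay on the whole organism (strain Kunming) with Mus musculus as the target, with a stated time of 0.5 h, at a dose of 300 mg/kg by the intraperitoneal route; a higher number here means a weaker effect of the compound at the dose given, a lower number a stronger effect. Compound 2 stands highest of the three numbers, and both neighbours lie beyond the usual scatter of this assay. Within the data shown here, the single step measured between compounds that differ in one place is a number 25 percentage points higher from compound 1 to compound 2 (beyond the scatter), a modest gain. Compound 3, which carries a tetramethoxy-substituted ring in place of the halogenated one, gives the same number as compound 1.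

Compound 4, `COc1ccc(/C=C/C(=O)OC/C=C/c2cc(OC)c(OC)cc2OC)cc1`, differs from compound 2 in one place: methoxy in place of chloro on an aromatic carbon. Among the measured compounds shown here, no measured step covers this exact change. For the measured compounds named here, the one step that bears on it shows that swapping the halogen in that position moves the number by a modest amount, and compound 3, which carries methoxy groups in place of a halogen, gives a low number. So a drop beyond the scatter is expected, roughly undoing the gain seen in compound 2, namely a number 20 percentage points lower from compound 2 to compound 4 (beyond the scatter). Compound 4 is therefore estimated at 5%, with a range from 0% to 25%.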

Compound 4, a percentage reported as activity, at one dose (the size of the read-out at that dose, not a potency): 0%
Compound 4: the middle estimate sits 5 percentage points above what was measured; the measured number falls inside the stated range.
By their numbers in this assay, from the lowest: compounds 1, 3 and 4 (each within the scatter of the next); then compound 2.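

In this assay the change from 4-chlorophenyl to 4-methoxyphenyl gives a number 25 percentage points lower from compound 2 to compound 4 (beyond the scatter), so a methoxy group at this place does not keep the weaker effect seen with chloro. Methoxy and fluoro read alike here, with no change at the digits printed from compound 1 to compound 4 (within the scatter), which means that chloro is the only one of these three groups that stands apart at this place. The data shown include no measurement that explains this difference.

From the compounds shown here alone, it remains open whether a bromo, an amino or a carboxylic acid group at this place would read like chloro or like fluoro and methoxy. Going by these compounds, it also remains open whether compound 1 and compound 4, which are indistinguishable at this single dose, would still match at a lower one.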